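The compounds below may be only part of what the source reports. "The series", "measured", "known", "first", "only" and "open" are said of these compounds alone.

Working notes on the series

Compound 2 `COc1cc(-c2nn(-c3cccc(NC(=O)Nc4cccc(C(F)(F)F)c4)c3)cc2-c2ccncc2)ccc1Cl` gives 2430 nM in a functional assay on NCI-H522 cells (Homo sapiens) for inhibition, read by sulforhodamine B assay, with a stated time of 48 h; a lower number here means a stronger inhibitor of growth, a higher number a weaker inhibitor of growth. Among the three numbers so far it stands lowest, though compound 1 `COc1cc(-c2nn(-c3cccc(NC(=O)c4cccc(C(F)(F)F)c4)c3)cc2-c2ccncc2)ccc1Cl`, at 3850 nM, lies within the scatter of it, the step being a 1.6-fold lower number from compound 1 to compound 2 (0.20 log units; within the scatter). Compound 3 `O=C(Nc1cccc(-n2cc(-c3ccncc3)c(-c3ccc(Cl)c(O)c3)n2)c1)Nc1cccc(C(F)(F)F)c1`, at 14500 nM, lies beyond the scatter, the step being a 6.0-fold higher number from compound 2 to compound 3 (0.78 log units; beyond the scatter).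

Compound 4 `COc1cc(-c2nn(-c3cccc(NC(=O)Nc4ccc(Cl)c(Cl)c4)c3)cc2-c2ccncc2)ccc1Cl` is not yet measured. It differs from compound 2 in one place: 3,4-dichlorophenyl in place of 3-(trifluoromethyl)phenyl on an amide-type nitrogen. For the measured compounds named here, no measured step alters the substitution on the terminal phenyl, so the change has no direct precedent here. The step from compound 1 to compound 2 touched the same end of the molecule and stayed within the scatter; the step from compound 2 to compound 3 concerns a different part and does not bear on this change. The expectation is therefore a step of a 1.1-fold higher number from compound 2 to compound 4 (0.03 log units; within the scatter), not beyond the scatter in either direction. Compound 4 is thus estimated at 2600 nM, with a range of 900 nM to 7500 nM.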

Compound 4, concentration for total growth inhibition: 3100 nM
Beside the measured number, compound 4's estimate is 1.2-fold (0.08 log units) below it; the range from low to high includes it.
By their numbers in this assay, from the lowest: compounds 2, 4 and 1 (each within the scatter of the next); then compound 3.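

In this assay, the substitution on the terminal phenyl now has a direct reading: 3,4-dichlorophenyl in place of 3-(trifluoromethyl)phenyl on an amide-type nitrogen gives a 1.3-fold higher number from compound 2 to compound 4 (0.11 log units; within the scatter), so this exchange leaves the number within the scatter of compound 2. The step of a 1.2-fold lower number from compound 1 to compound 4 (0.09 log units; within the scatter), with (3,4-dichlorophenyl)amino in place of 3-(trifluoromethyl)phenyl on a carbonyl carbon, alters that same end of the molecule more widely and also stays within the scatter. No supporting data accompany these steps to account for them.

Going by these compounds, whether a terminal phenyl carrying an amine or a carboxylic acid would move the number beyond the scatter remains open. Also open, on these data alone, is whether hydrogen in place of methyl on the aromatic oxygen gives a comparable step when 3,4-dichlorophenyl is present.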